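Hydrazone aryl swap in a cytotoxicity series

The compounds below may be only part of what the source reports. "The series", "measured", "known", "first", "only" and "open" are said of these compounds alone.

Measured compounds:
compound 1, `COc1cc2c(Oc3ccc(NC(=O)N/N=C/c4ccc([N+](=O)[O-])cc4)cc3F)ccnc2cc1OCCCN1CCCC1`: 970 nM
compound 2, `COc1ccc(/C=N/NC(=O)Nc2ccc(Oc3ccnc4cc(OCCCN5CCCCC5)c(OC)cc34)c(F)c2)cc1`: 840 nM

Both measured compounds were tested in a functional assay on MDA-MB-231 cells (Homo sapiens) for cytotoxicity, read by MTT assay, with a stated time of 72 h; a higher number here means a weaker inhibitor, a lower number a stronger inhibitor. Compound 1 gives 970 nM and compound 2 gives 840 nM; the two numbers sit within the usual scatter of one another, so compound 2 cannot be set apart from compound 1 on these data. Going by the values given here, compound 1 and compound 2 differ in more than one place, so their pair gives no clean single-point step to lean on.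

The unmeasured compound 3, `COc1cc2c(Oc3ccc(NC(=O)N/N=C/c4ccc(Cl)cc4Cl)cc3F)ccnc2cc1OCCCN1CCCCC1`, is taken from compound 2 by one change: 2,4-dichlorophenyl in place of 4-methoxyphenyl on a carbon with a double bond to nitrogen. The rest of the structure, including the basic side chain of compound 2, is kept.

Among the compounds with values here, with only two measured compounds, both at nearly the same level, nothing yet shows that the aryl group on the hydrazone carbon moves the number far. The step of a 1.1-fold lower number from compound 2 to compound 3 (0.05 log units; within the scatter) is therefore expected to stay within or close to the scatter, with no clear direction. Compound 3 is estimated at 750 nM, with a range from 300 nM to 1800 nM.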

Compound 3, half-maximal inhibitory concentration: 750 nM
For compound 3 middle estimate and measured number coincide at the digits printed; the range from low to high includes it.
By their numbers in this assay, from the lowest: compounds 3, 2 and 1 (each within the scatter of the next).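

Working notes on the hydrazone aryl position: in this assay, placing 2,4-dichlorophenyl in place of 4-methoxyphenyl on a carbon with a double bond to nitrogen gives a 1.1-fold lower number from compound 2 to compound 3 (0.05 log units; within the scatter), the first single-point step available at this position. The piperidine-bearing pair therefore shows that these two aryl groups, one carrying a methoxy group and the other two chlorine atoms, cannot be told apart in this read-out, something the earlier comparison of compound 1 and compound 2 could not show, as those compounds differ in more than one place. No supporting measurement is available to explain this flat step.

One step between two substituted phenyl groups does not establish that the position is insensitive in general, and a 4-aminophenyl group, a 4-carboxyphenyl group or a plain methyl group in place of the aryl ring could still move the number well beyond the scatter. From the compounds shown here alone, it also remains open whether the same flat result would be seen with the pyrrolidine side chain of compound 1, or whether the aryl group and the side chain act independently of each other.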